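Hydroxy for vinyl in compound 3: working notes

The source may report more compounds than this note shows. Statements on the series, on what has been measured and on what is new or still open speak of the compounds shown alone.

Measured so far:
compound 1 `O=S(=O)(Nc1ccc(-c2nc3ccccc3o2)cc1)c1cccc(F)c1` — 71000 nM
compound 2 `CS(=O)(=O)Nc1ccc(-c2nc3cc(NS(=O)(=O)c4ccc(Cl)s4)ccc3o2)cc1` — 43000 nM
compound 3 `C=Cc1ccc(S(=O)(=O)Nc2ccc3oc(-c4ccccc4)nc3c2)cc1` — > 100000 nM

The read-out throughout is an assay on cells for inhibition of HSP60/HSP10 (Homo sapiens), with a stated time of 60 min; on this read-out higher numbers stand for weaker inhibition and lower numbers for stronger inhibition. Compound 1 gives 71000 nM and compound 2 gives 43000 nM; both are weak. For compound 3 the assay reports no number, only a limit, > 100000 nM. Compound 3 therefore stands at the limit of > 100000 nM in this assay, at which 1 of the 3 values shown sits. Its position against the two numbered values cannot be fixed closer than that it is not stronger than either of them on what the numbers show.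

Compound 4 `O=S(=O)(Nc1ccc2oc(-c3ccccc3)nc2c1)c1ccc(O)cc1` is the next member and is not yet measured. Against compound 3 the change is hydroxy in place of vinyl on an aromatic carbon.

Going by the values given here, no step between two measured compounds is available in this set, so the size of such a change cannot be read from the series itself. With compound 3 at the limit, the expectation for compound 4 is a value near that limit, possibly still at it; the step of an at least 1.2-fold lower number from compound 3 to compound 4 (0.09 log units; that floor lies within the scatter) is expected to be no larger than the scatter, with a slight lean toward a readable number rather than another limit. Compound 4 is estimated at 80000 nM. For compound 4 the expected range runs from 30000 nM to 250000 nM.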

Compound 4, half-maximal inhibitory concentration: 88000 nM
Compound 4: the middle estimate sits 1.1-fold (0.04 log units) below what was measured; low and high end bracket the measured number.
By their numbers in this assay, from the lowest: compounds 2, 1 and 4 (each within the scatter of the next, the first and the last beyond it). At a limit, above all of these: compound 3.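

Going by these compounds alone, replacing 4-vinylphenyl with 4-hydroxyphenyl gives the first single-place step, and in this assay it reads as an at least 1.1-fold lower number from compound 3 to compound 4 (0.05 log units; that floor lies within the scatter). Within the data shown here, compound 3 remains the only compound at a limit, so this step has a known floor but no known size: the limit of > 100000 nM in this assay, at which 1 of the 4 values shown sits. On an aromatic carbon para to a large group, hydroxy gives a readable number, with compound 4 at 88000 nM. The floor of the step does not show a gain over vinyl that clears the scatter.

Still open, from the compounds shown here alone, is whether another group at this place, such as an amine, a carboxylic acid or a longer chain, would move the number beyond the scatter from compound 4. Also open, going by these compounds, are the true distance between compound 3 and compound 4, which a limit cannot give, and whether hydroxy in place of vinyl would give a step of readable size on a partner that gives a number rather than a limit in this assay.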